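The source may report more compounds than this note shows. Statements on the series, on what has been measured and on what is new or still open speak of the compounds shown alone.

Measured compounds:
compound 1 `O=S(=O)(NCCCNCc1cccc2ccccc12)c1cc(C(F)(F)F)cc(C(F)(F)F)c1`, 1400 nM
compound 2 `O=S(=O)(NCCCNCc1ccc(Cl)cc1)c1cc(C(F)(F)F)cc(C(F)(F)F)c1`, 2400 nM
compound 3 `CC(C)(C)c1ccc(CNCCCNS(=O)(=O)c2cc(C(F)(F)F)cc(C(F)(F)F)c2)cc1`, 2100 nM

In a functional assay on MCF7 cells (Homo sapiens) for inhibition, read by MTT assay, with a stated time of 72 h (a higher number here means a weaker inhibitor of growth, a lower number a stronger inhibitor of growth), compound 1 gives the lowest of the three numbers, but its neighbours sit within the scatter of it: a 1.5-fold higher number from compound 1 to compound 3 (0.18 log units; within the scatter) and a 1.7-fold higher number from compound 1 to compound 2 (0.23 log units; within the scatter), and between the two single-ring analogues a 1.1-fold lower number from compound 2 to compound 3 (0.06 log units; within the scatter). Within the data shown here, no compound can be called more or less potent than another on these numbers.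

Compound 4 `COc1cccc(CNCCCNS(=O)(=O)c2cc(C(F)(F)F)cc(C(F)(F)F)c2)c1` is not yet measured. It differs from compound 1 as follows: 3-methoxyphenyl in place of naphthalen-1-yl on a saturated chain carbon bound to an amine nitrogen. The two steps that bear on it, from compound 1 to compound 2 and from compound 1 to compound 3, both swap the same naphthalen-1-yl for a single six-membered aromatic ring and both stay within the scatter. The present swap, to a 3-methoxyphenyl, is expected to behave alike, with no step beyond the scatter in either direction. The expected step is a 1.4-fold higher number from compound 1 to compound 4 (0.15 log units; within the scatter). Compound 4 is thus estimated at 2000 nM, within the range 1000 nM to 4500 nM.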

Compound 4, concentration for 50% growth inhibition: 2400 nM
Estimate against measurement, compound 4: 1.2-fold (0.08 log units) below; measured number inside the range.
By their numbers in this assay, from the lowest: compounds 1, 3, 2 and 4 (each within the scatter of the next).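

In this assay, 3-methoxyphenyl brings an oxygen and a hydrogen-bond acceptor to this position, which naphthalen-1-yl lacks, yet every step stays within the scatter: a 1.7-fold higher number from compound 1 to compound 4 (0.23 log units; within the scatter), a 1.1-fold higher number from compound 3 to compound 4 (0.06 log units; within the scatter) and no change at the digits printed from compound 2 to compound 4 (within the scatter). The series at this position therefore now spans both ring count and an added acceptor without a step beyond the scatter. Nothing available explains this flat response.

Still open, going by these compounds, is whether a carboxylic acid or an amine on the ring, or a plain alkyl group in place of the ring, would give a step beyond the scatter. On these data alone, a longer chain between the two nitrogens is equally open.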